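A few compounds are considered here, and "the series" means these few. Any claim that something is new, unique, unknown or untested is made for them only; others in the source may bear on it.

Compound 1 `COc1ccc(Oc2ccc(C(C)C)cc2-c2ccsc2S(=O)(=O)NCCNC(=S)Nc2ccc([N+](=O)[O-])cc2)cc1OC` gives 11900 nM in a functional assay on HeLa cells (Homo sapiens) for inhibition, read by CCK-8 assay, with a stated time of 48 h; a higher number here means a weaker inhibitor, a lower number a stronger inhibitor. Compound 2 `Cc1ccc(-c2ccsc2S(=O)(=O)NCCNC(=O)Nc2cc(C(F)(F)F)cc(C(F)(F)F)c2)c(Oc2ccc(O)c(O)c2)c1` gives 9700 nM in this assay. Compound 3 `CC(C)c1ccc(Oc2ccc(O)c(O)c2)c(-c2ccsc2S(=O)(=O)NCCNC(=S)Nc2ccc([N+](=O)[O-])cc2)c1` reaches only a limit in this assay, > 20000 nM.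

From the compounds shown here alone, compound 1 and compound 3 differ by 3,4-dimethoxyphenyl in place of 3,4-dihydroxyphenyl on an oxygen on an aromatic ring, and that change brings an at least 1.6-fold lower number from compound 3 to compound 1 (0.22 log units; that floor lies within the scatter); since the starting point is a limit (the limit of > 20000 nM in this assay, at which 1 of the 3 values shown sits), the true size of this step stays open. Compound 4 `COc1ccc(Oc2cc(C)ccc2-c2ccsc2S(=O)(=O)NCCNC(=O)Nc2cc(C(F)(F)F)cc(C(F)(F)F)c2)cc1OC` carries the same change from compound 2, (3,4-dimethoxyphenyl in place of 3,4-dihydroxyphenyl on an oxygen on an aromatic ring), at a place described in the same words. How the core of compound 2 differs from the core of compound 3 is not broken down here. The numbers of compound 1 and compound 2 lie within the scatter of each other. Because the measured step of an at least 1.6-fold lower number from compound 3 to compound 1 (0.22 log units; that floor lies within the scatter) is only a floor within the scatter, compound 4 is expected to show a 1.4-fold lower number from compound 2 to compound 4 (0.14 log units; within the scatter) in this assay. Compound 4 is expected to give 7000 nM, with a range from 3000 nM to 20000 nM.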

Compound 4, half-maximal inhibitory concentration: 10200 nM
Compound 4: the middle estimate sits 1.5-fold (0.16 log units) below what was measured; the range from low to high includes it.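

In this assay, the change from 3,4-dihydroxyphenyl to 3,4-dimethoxyphenyl brings a 1.1-fold higher number from compound 2 to compound 4 (0.02 log units; within the scatter). From the compounds shown here alone, this neither shows that the change carries over unaltered from one core to another nor shows that it does not: the same change on two cores in this assay, an at least 1.6-fold lower number (0.22 log units; that floor lies within the scatter) from compound 3 to compound 1 and a 1.1-fold higher number (0.02 log units; within the scatter) from compound 2 to compound 4; the limit leaves it open whether they differ Compound 3 gives only a limit, > 20000 nM, and the size of the step on its core stays unknown.

The compounds shown leave open what an amine or a carboxylic acid on that aromatic ring, in place of the methoxy groups, would give in this assay. They also leave open whether a core that gives a number at both ends of the change would show a step of similar size.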